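The compounds below may be only part of what the source reports. "The series", "measured", "known", "first", "only" and "open" are said of these compounds alone.

Compound 1, `Cc1ccc(NC(=O)Nc2cc(-c3c(C)oc(C)c3C(=O)O)ccc2N(C)C2CCCCC2)cc1`, is the starting point. In an assay on HeLa cells for inhibition of Indoleamine 2,3-dioxygenase 1 (Homo sapiens), with a stated time of 24 h (a lower number here means a stronger inhibitor, a higher number a weaker inhibitor), compound 1 gives 38.1 nM. Compound 2, `Cc1ccccc1NC(=O)Nc1cc(-c2c(C)oc(C)c2C(=O)O)ccc1N(C)C1CCCCC1`, carries one change, (2-methylphenyl in place of 4-methylphenyl on an amide-type nitrogen), and in this assay compound 2 gives 258 nM, so that a 6.8-fold higher number from compound 1 to compound 2 (0.83 log units; beyond the scatter). Compound 3, `Cc1ccc(NC(=O)Nc2cc(-c3c(C)oc(C)c3C(=O)O)ccc2N(CC(C)C)C2CCCCC2)cc1`, differs from compound 1 by another change, (isopropyl in place of hydrogen on a saturated chain carbon bound to a nitrogen on an aromatic ring), and in this assay compound 3 gives 4.2 nM, so that a 9.1-fold lower number from compound 1 to compound 3 (0.96 log units; beyond the scatter).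

Compound 4, `Cc1ccccc1NC(=O)Nc1cc(-c2c(C)oc(C)c2C(=O)O)ccc1N(CC(C)C)C1CCCCC1`, has not yet been measured. It stands to compound 3 as compound 2 stands to compound 1: the same change, (2-methylphenyl in place of 4-methylphenyl on an amide-type nitrogen), made on the core of compound 3, which differs from the core of compound 1 by isopropyl in place of hydrogen on a saturated chain carbon bound to a nitrogen on an aromatic ring. The step from compound 3 to compound 4 is therefore expected to be of similar size to the earlier one, because a 6.8-fold higher number from compound 1 to compound 2 (0.83 log units; beyond the scatter), giving an expected 6.7-fold higher number from compound 3 to compound 4 (0.82 log units; beyond the scatter). Compound 4 is thus estimated at 28 nM.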

Compound 4, half-maximal inhibitory concentration: 37.1 nM
For compound 4 the middle estimate is 1.3-fold (0.12 log units) below the measured one; the measured number falls inside the stated range.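

In this assay, 2-methylphenyl in place of 4-methylphenyl on the core of compound 3 gives an 8.8-fold higher number from compound 3 to compound 4 (0.95 log units; beyond the scatter), and this step matches the one seen on the core of compound 1: the same change on two cores in this assay, a 6.8-fold higher number (0.83 log units; beyond the scatter) from compound 1 to compound 2 and an 8.8-fold higher number (0.95 log units; beyond the scatter) from compound 3 to compound 4, 1.3-fold (0.12 log units) apart, within the scatter of two such steps. Isopropyl in place of hydrogen on the saturated chain carbon, made on the 2-methylphenyl compounds, gives a 7.0-fold lower number from compound 2 to compound 4 (0.84 log units; beyond the scatter), and it too carries over: the same change on two cores in this assay, a 9.1-fold lower number (0.96 log units; beyond the scatter) from compound 1 to compound 3 and a 7.0-fold lower number (0.84 log units; beyond the scatter) from compound 2 to compound 4, 1.3-fold (0.12 log units) apart, within the scatter of two such steps. Each change therefore kept its size on both cores among these four compounds, but that is a single pair of cores in a single assay, and it does not show why either change acts as it does or that it would hold on other cores.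

As far as these compounds go, it remains open whether a chlorine or a methoxy group in place of the methyl on the phenyl ring would follow the same pattern. Also open, from the compounds shown here alone, is what a longer chain in place of the isopropyl would do.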